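The compounds below may be only part of what the source reports. "The series", "measured", "known", "first", "only" and "open" are said of these compounds alone.

Compound 2 `O=C(NO)C(F)(F)C(F)(F)C(F)(F)C(F)(F)C(F)(F)C(F)(F)C(=O)Nc1ccc(I)cc1` stands in an ADME assay on isolated protein for inhibition of histone deacetylase 4 (Homo sapiens), read by fluorescence, with stated times of 30 min and 60 min (on this read-out lower numbers stand for stronger inhibition and higher numbers for weaker inhibition), only at a limit, > 50000 nM, which is not a number. Compound 1 `Cc1cccc(NC(=O)C(F)(F)C(F)(F)C(F)(F)C(F)(F)C(F)(F)C(F)(F)C(=O)NO)c1` likewise gives only a limit in this assay, > 50000 nM. The step that the two limits leave unreadable from compound 1 to compound 2 is accordingly not readable, and the limit of > 50000 nM in this assay, at which 2 of the 2 values shown sit, is the whole of the evidence. Compound 3 `CC(=O)Nc1ccc(NC(=O)C(F)(F)C(F)(F)C(F)(F)C(F)(F)C(F)(F)C(F)(F)C(=O)NO)cc1` differs from compound 2 by acetamido in place of iodo on an aromatic carbon. For the measured compounds named here, with both measured values sitting at the limit, no size of step can be taken from them, and a further limit is the natural expectation. Compound 3 is therefore estimated at 60000 nM, with a range from 20000 nM to 200000 nM. The step this estimate means is expected to read a step that the limit leaves unreadable from compound 2 to compound 3.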

Compound 3, inhibition constant: > 50000 nM
Compound 3 ended at the assay's limit; the forecaster's own chance of this, stated with the estimate: 85%; the middle value does not contradict the limit.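

No step can be read among compound 1, compound 2 and compound 3, since each gives only a limit: the limit of > 50000 nM in this assay, at which 3 of the 3 values shown sit. The compounds shown leave open how they rank, and whether any group on the amide-type nitrogen of the shared core gives a readable inhibition constant.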